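Swapping the ring-nitrogen substituent of compound 3 for 4-fluorobenzyl

A few compounds are considered here, and "the series" means these few. Any claim that something is new, unique, unknown or untested is made for them only; others in the source may bear on it.

Of the compounds shown here, three sharing one core have been measured in an assay on HEK-293T cells for antagonist activity at vitamin D3 receptor (Homo sapiens), read by a luciferase reporter, with a stated time of 24 h; on this read-out lower numbers stand for stronger inhibition and higher numbers for weaker inhibition. Compound 1 `CCC(CC)n1c(-c2ccc(OCc3c(-c4c(Cl)cccc4Cl)noc3C(C)C)cc2)nc2ccc(C(=O)O)cc21` gives 5690 nM, compound 2 `CC(C)c1onc(-c2c(Cl)cccc2Cl)c1COc1ccc(-c2nc3ccc(C(=O)O)cc3n2C(C)C)cc1` gives 3550 nM, and compound 3 `CC(C)c1onc(-c2c(Cl)cccc2Cl)c1COc1ccc(-c2nc3ccc(C(=O)O)cc3n2C2CCCCCC2)cc1` gives 921 nM. Compound 3 stands lowest of the three: its nearest neighbour is compound 2, reached by a 3.9-fold lower number from compound 2 to compound 3 (0.59 log units; beyond the scatter), and its furthest is compound 1, reached by a 6.2-fold lower number from compound 1 to compound 3 (0.79 log units; beyond the scatter). The remaining step, a 1.6-fold lower number from compound 1 to compound 2 (0.20 log units; within the scatter), does not separate those two compounds.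

Compound 4 `CC(C)c1onc(-c2c(Cl)cccc2Cl)c1COc1ccc(-c2nc3ccc(C(=O)O)cc3n2Cc2ccc(F)cc2)cc1` is not yet measured. It differs from compound 3 by 4-fluorobenzyl in place of cycloheptyl on an aromatic nitrogen. All three measured steps concern the group on the same aromatic nitrogen, so they bear directly on this change, although none of them introduces a 4-fluorobenzyl or any aromatic substituent there. The measured steps show that exchanging one group for another at this position can shift the number by a modest amount in either direction, and the move to 4-fluorobenzyl is of a kind not yet tested, so a modest rise in the number back toward compound 2 is judged slightly more likely than a further fall. Compound 4 is therefore expected to give about 1600 nM, with a plausible range from 500 nM to 5000 nM, a step estimated as a 1.7-fold higher number from compound 3 to compound 4 (0.24 log units; within the scatter).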

Compound 4, half-maximal inhibitory concentration: 1140 nM
The estimate for compound 4 lay 1.4-fold (0.15 log units) above the measured number; low and high end bracket the measured number.
By their numbers in this assay, from the lowest: compounds 3 and 4 (each within the scatter of the next); then compounds 2 and 1 (each within the scatter of the next).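

In this assay, going by these compounds alone, the first aromatic group at this position, on an aromatic nitrogen of the five-membered ring, does not separate compound 4 from compound 3 (a 1.2-fold higher number from compound 3 to compound 4 (0.09 log units; within the scatter)), so a seven-membered non-aromatic ring of carbon only and a 4-fluorobenzyl group are not told apart here. Compound 4 also stands clear of the compounds carrying isopropyl (a 3.1-fold lower number from compound 2 to compound 4 (0.49 log units; beyond the scatter)) and pentan-3-yl (a 5.0-fold lower number from compound 1 to compound 4 (0.70 log units; beyond the scatter)), and with this result the two groups that hold a ring, cycloheptyl and 4-fluorobenzyl, both stand apart from the two that hold none, with no compound among these four going against that. Nothing measured in this set accounts for this grouping.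

Going by these compounds, it remains open whether the fluorine of the 4-fluorobenzyl group plays any part, which a plain benzyl group would test, and whether the aromatic ring can be moved further from the nitrogen, as in a 2-phenylethyl group. Equally open, on these data alone, is how a group bearing an amine or a hydroxyl on the same nitrogen would fare, or how a cyclopentyl ring would compare with cycloheptyl.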